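The compounds below may be only part of what the source reports. "The series", "measured", "known", "first", "only" and "open" are said of these compounds alone.

Compound 1 `COc1cc2[nH]c(C)c(-c3ccc(Oc4ccc(F)cc4)cc3)c(=O)c2cc1Cl` gives > 10000 nM in an ADME assay on HepG2 cells (Homo sapiens) for cytotoxicity, read by resazurin assay, with a stated time of 24 h (a lower number here means a stronger inhibitor, a higher number a weaker inhibitor), a limit of the assay rather than a number.
Compound 2 `Cc1[nH]c2ccccc2c(=O)c1-c1ccc(Oc2ccc(OC(F)(F)F)cc2)cc1` gives > 10000 nM in this assay, again a limit.
Compound 3 `COc1cc2[nH]c(C)c(-c3ccc(Oc4ccc(F)c(OC(F)(F)F)c4)cc3)c(=O)c2cc1Cl` gives > 10000 nM in this assay, also a limit.

Compound 4 `Cc1[nH]c2ccccc2c(=O)c1-c1ccc(Oc2ccccc2)cc1` has not yet been measured in this assay. It differs from compound 2 by hydrogen in place of trifluoromethoxy on an aromatic carbon. The same kind of change links compound 3 to compound 1, (hydrogen in place of trifluoromethoxy on an aromatic carbon), though there the place is ortho to a fluoro group and meta to a large group, while in compound 4 it is para to a large group. The step that the two limits leave unreadable from compound 3 to compound 1 cannot be read because both values sit at the limit of > 10000 nM in this assay, at which 3 of the 3 values shown sit. The difference between the cores of compound 2 and compound 3 is not broken down here. Because every measured value rests at the limit of > 10000 nM in this assay, at which 3 of the 3 values shown sit, the expected step that the limit leaves unreadable from compound 2 to compound 4 is taken as flat, with another limit the likeliest outcome. Compound 4 is estimated at 15000 nM.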

Compound 4, half-maximal inhibitory concentration: > 10000 nM
Compound 4: a limit, no number (the forecaster's own chance of this, stated with the estimate: 80%); the middle value lies beyond the limit too.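

No step can be read from compound 2 to compound 4, since both values are limits rather than numbers: the limit of > 10000 nM in this assay, at which 4 of the 4 values shown sit.

The compounds shown leave open whether swapping trifluoromethoxy for hydrogen changes the result in this assay at all, and what concentration would reach half-maximal inhibition.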